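Trifluoromethyl for Cyano on an Aryl-Substituted Core

The compounds below may be only part of what the source reports. "The series", "measured", "known", "first", "only" and "open" are said of these compounds alone.

Compound 1 `COC(=O)c1sc2cc(-c3cnc4ccccc4c3)cnc2c1N` gives 9100 nM in a functional assay on A-375 cells (Homo sapiens) for inhibition, read by sulforhodamine B assay, with a stated time of 48 h (a higher number here means a weaker inhibitor of growth, a lower number a stronger inhibitor of growth), and compound 2 `COC(=O)c1sc2cc(-c3ccc4c(ccn4C)c3)cnc2c1N` gives 21200 nM. Compound 3 `COC(=O)c1sc2cc(-c3ccc(C#N)cc3)cnc2c1N` reaches only a limit of this assay, > 75000 nM, so its place among the measured values is known only as a limit (the limit of > 75000 nM in this assay, at which 1 of the 3 values shown sits). Compound 4 `COC(=O)c1sc2cc(-c3ccc(C(F)(F)F)cc3)cnc2c1N` differs from compound 3 by trifluoromethyl in place of cyano on an aromatic carbon. For the measured compounds named here, no step between measured compounds stands beside this change, so nothing measured sets its size. The step from compound 3 to compound 4 in this assay is expected to be a step that the limit leaves unreadable from compound 3 to compound 4, no more than the scatter. Compound 4 is therefore estimated at 80000 nM, within 30000 nM to 200000 nM, and most likely reported again only as a limit.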

Compound 4, concentration for 50% growth inhibition: > 150000 nM
Compound 4: only a limit was reported; the forecaster's own chance of this, stated with the estimate: 70%; middle value at least 1.8-fold (0.27 log units) from the limit.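

In this assay, for the compounds shown here, compound 3 and compound 4 are both reported only as limits, and no step between them can be read. The compounds shown leave open whether trifluoromethyl in place of cyano changes growth inhibition at all.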